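The source may hold more compounds than are shown below. What is called first, only, known or untested is meant among the compounds shown, and "the series" means these compounds.

Working notes on the series in an ADME assay on L02 cells (Homo sapiens) for cytotoxicity, read by MTT assay, with a stated time of 48 h; on this read-out lower numbers stand for stronger inhibition and higher numbers for weaker inhibition.

Compound 1 `O=C1CSC(=O)N1C[C@H]1CN(c2ccc(-n3cc(-c4ccccn4)cn3)c(F)c2)C(=O)O1` carries 2,4-dioxo-1,3-thiazolidin-3-yl on a saturated chain carbon bound to a saturated ring carbon. In this assay compound 1 reaches only a limit, > 400 ug/mL, and not a number. Compound 2 `CCC(=O)NC[C@H]1CN(c2ccc(-n3cc(-c4ccccn4)cn3)c(F)c2)C(=O)O1` carries propanoylamino at the same place. In this assay compound 2 gives 204 ug/mL. For the measured compounds named here, the step of an at least 1.9-fold lower number from compound 1 to compound 2 (0.29 log units; that floor lies within the scatter) is the only measured step in the set, and its floor lies within the usual scatter. Compound 2 therefore holds the only number shown. The other value shown is the limit of > 400 ug/mL in this assay, at which 1 of the 2 values shown sits, which belongs to compound 1.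

Compound 3 `CNC(=O)[C@H]1CN(c2ccc(-n3cc(-c4ccccn4)cn3)c(F)c2)C(=O)O1` differs from compound 2 by methylcarbamoyl in place of (propanoylamino)methyl on a saturated ring carbon. Going by the values given here, only the step from compound 1 to compound 2 bears on this change, since it is the only step measured, and it gave no movement beyond the scatter. The expected outcome is thus a step of a 1.2-fold higher number from compound 2 to compound 3 (0.09 log units; within the scatter) of no settled direction, with a fair chance that this assay again returns only a limit. Compound 3 is estimated at 250 ug/mL, within 120 ug/mL to 450 ug/mL.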

Compound 3, half-maximal inhibitory concentration: 217 ug/mL
Compound 3: middle estimate off by 1.2-fold (0.06 log units), on the high side; the measured number falls inside the stated range.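

The new result shows that, in this assay, this saturated ring carbon next to the ring oxygen accepts methylcarbamoyl in place of (propanoylamino)methyl with no readable movement (a 1.1-fold higher number from compound 2 to compound 3 (0.03 log units; within the scatter)). The two groups share a carbonyl-bearing amide form and the same hydrogen-bond donor and acceptor counts, but differ in size, with 4 heavy atoms against 6, and this difference in size and in the attachment of the amide leaves compound 2 and compound 3 within the scatter of each other. The replacement of (2,4-dioxo-1,3-thiazolidin-3-yl)methyl by methylcarbamoyl gives a second comparison whose floor also stays within the scatter (an at least 1.8-fold lower number from compound 1 to compound 3 (0.26 log units; that floor lies within the scatter)), and the value of compound 1 is a limit and not a number: the limit of > 400 ug/mL in this assay, at which 1 of the 3 values shown sits.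

As far as these compounds go, compounds 2 and 3 both hold an amide at this place, so it remains open whether a primary amine, a carboxylic acid or a longer chain on the same saturated ring carbon would move the number beyond the scatter in this assay. From the compounds shown here alone, it also remains open whether the result for methylcarbamoyl would hold with a different group on the shared core.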